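Branching the ester chain: from compound 2 to compound 3

The compounds below may be only part of what the source reports. "The series", "measured", "known", "first", "only" and "open" are said of these compounds alone.

Measured so far:
compound 1, `CC(=O)OCc1ccc2oc(=O)c(C(=O)Nc3cccc(Cl)c3)cc2c1`, 42.8%
compound 2, `CCC(=O)OCc1ccc2oc(=O)c(C(=O)Oc3cccc(Br)c3)cc2c1`, 21.3%

In a functional assay on HT-1080 cells (Homo sapiens), read by transwell migration, with a stated time of 24 h, tested at 10 uM (on this read-out lower numbers stand for a stronger effect and higher numbers for a weaker effect at the one concentration tested), compound 2 gives the lowest of the two numbers; compound 1 sits higher by a gap beyond the usual scatter. Compound 3, `CC(C)C(=O)OCc1ccc2oc(=O)c(C(=O)Oc3cccc(Br)c3)cc2c1`, is not yet measured. It differs from compound 2 by methyl in place of hydrogen on a saturated chain carbon bound to a carbonyl carbon and a saturated chain carbon. Going by the values given here, no pair of measured compounds differs in only one place, so nothing measured shows what such a change does here. The step of a number 2.7 percentage points higher from compound 2 to compound 3 (within the scatter) is expected to be small, with no shift beyond the scatter. Compound 3 is estimated at 24% in this assay, with a range from 10% to 40%.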

Compound 3, a percentage reported as activity, at one concentration (the size of the read-out at that concentration, not a potency): 21.1%
Beside the measured number, compound 3's estimate is 2.9 percentage points above it, within the range that was stated.
By their numbers in this assay, from the lowest: compounds 3 and 2 (each within the scatter of the next); then compound 1.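

In this assay, going by these compounds alone, the first single-place change, propanoyl to isopropylcarbonyl, gives a number 0.2 percentage points lower from compound 2 to compound 3 (within the scatter). At this saturated chain carbon, methyl in place of hydrogen therefore leaves compound 2 and compound 3 indistinguishable at the one concentration tested. No available measurement bears on the reason for this result.

From the compounds shown here alone, it remains open whether a longer chain, such as butanoyl, or an amine on the same chain would also stay within the scatter of compound 2. Going by these compounds, the effect of the same branching with the amide linkage of compound 1 also remains open.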